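The compounds below may be only part of what the source reports. "The series", "measured", "known", "first", "only" and "open" are said of these compounds alone.

Two sulfamate compounds with a shared core have been tested in an assay on HEK293 cells for inhibition of Steryl-sulfatase (Homo sapiens), tested at 0.1 uM; a lower number here means a weaker effect, a higher number a stronger effect of the compound at the concentration tested. Compound 1 `NS(=O)(=O)Oc1ccc2c(c1)CN(C(=O)c1ccc(N3CCC(N4CCCCC4)CC3)cc1)CC2` gives 8.5% in this assay. Compound 2 `CC(C)CCN(CCC(C)C)c1cccc(C(=O)N2CCc3ccc(OS(N)(=O)=O)cc3C2)c1` gives 32.3% in this assay, the higher of the two numbers, and its distance from compound 1 lies beyond the usual scatter of this measurement. Compound 3 `CN(CCN1CCCCC1)c1cccc(C(=O)N2CCc3ccc(OS(N)(=O)=O)cc3C2)c1` has not yet been measured. It differs from compound 2 in one place: methyl(2-(piperidin-1-yl)ethyl)amino in place of diisopentylamino on an aromatic carbon. The entering group brings one six-membered non-aromatic ring with one hetero atom and a second hydrogen-bond acceptor, where the leaving group had no ring. Compound 1 stands low in this assay. Compound 3 is expected to fall against compound 2, with a step of a number 17.3 percentage points lower from compound 2 to compound 3 (beyond the scatter) beyond the scatter, because compound 1 gives only 8.5%. Compound 3 is therefore estimated at 15% in this assay, within a range of 3% to 35%.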

Compound 3, a percentage reported as inhibition, at one concentration (the size of the read-out at that concentration, not a potency): 24.5%
Compound 3: the middle estimate sits 9.5 percentage points below what was measured; low and high end bracket the measured number.
By their numbers in this assay, from the lowest: compound 1; then compounds 3 and 2 (each within the scatter of the next).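

In this assay, placing methyl(2-(piperidin-1-yl)ethyl)amino in place of diisopentylamino on an aromatic carbon, meta to a large group, gives a step of a number 7.8 percentage points lower from compound 2 to compound 3 (within the scatter). At this position, then, a group with no ring and a group with one six-membered non-aromatic ring and a second hydrogen-bond acceptor cannot be told apart by this read-out, so the two amines can be treated as equal here. No measurement at hand bears on why the two groups read alike.

Going by these compounds, both readings come from a single concentration, so whether compound 2 and compound 3 would also match in potency stays open. Also open, on these data alone, is how this position would read with a small dimethylamino group, a morpholine ring or a carboxylic acid.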